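A few compounds are considered here, and "the series" means these few. Any claim that something is new, unique, unknown or untested is made for them only; others in the source may bear on it.

Compound 1 `CCCCCCCCCCCCCC[C@H](O)[C@H](CO[Si](c1ccccc1)(c1ccccc1)C(C)(C)C)NC(=O)OC(C)(C)C` gives 10.4%.
Compound 2 `CCCCCCCCCCCCCC[C@H](OCOC)[C@H](CO[Si](c1ccccc1)(c1ccccc1)C(C)(C)C)NC(=O)OC(C)(C)C` gives -14.6%.
Compound 3 `CCCCCCCCCCCCCC[C@H](OCOC)[C@H](CO)NC(=O)OC(C)(C)C` gives 54.8%.

In a functional assay on DLD-1 cells (Homo sapiens) for antiproliferative activity, read by sulforhodamine B assay, with a stated time of 48 h, tested at 10 uM (a higher number here means more inhibition at the concentration tested (going by the name of the read-out), a lower number less inhibition), compound 3 stands highest of the three measured compounds, beyond the scatter above both compound 1 and compound 2. Compound 4 `CCCCCCCCCCCCCC[C@H](OCOC)[C@H](CN(C(C)C)C(C)C)NC(=O)OC(C)(C)C` differs from compound 3 by diisopropylamino in place of hydroxy on a saturated chain carbon, two bonds along the chain from an amide-type nitrogen. Among the measured compounds shown here, the only measured step, a number 25 percentage points lower from compound 1 to compound 2 (beyond the scatter), concerns a different change, methoxymethyl in place of hydrogen on an oxygen, and so does not bear on this one. For the measured compounds named here, no measured step speaks to the exchange of a hydroxy for a diisopropylamino, so the direction of the step is uncertain; compound 4 is expected to show a step of a number 9.8 percentage points lower from compound 3 to compound 4 (within the scatter). Compound 4 is therefore estimated at 45%, within a range from 15% to 75%.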

Compound 4, a percentage reported as inhibition, at one concentration (the size of the read-out at that concentration, not a potency): 53.9%
Compound 4: the middle estimate sits 8.9 percentage points below what was measured, within the range that was stated.
By their numbers in this assay, from the lowest: compound 2; then compound 1; then compounds 4 and 3 (each within the scatter of the next).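

In this assay, diisopropylamino in place of hydroxy on a saturated chain carbon, two bonds along the chain from an amide-type nitrogen, gives a number 0.9 percentage points lower from compound 3 to compound 4 (within the scatter). This position therefore accepts a much larger group without a measurable loss of inhibition. A free hydroxy at this place is thus not required for the level of inhibition seen with compound 3 , which gives 54.8% in this series.

On these data alone, whether a primary amine, a morpholine or a carboxylic acid at this place would read the same remains open. Nothing shown explains why hydroxy and diisopropylamino read alike here.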